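The source may hold more compounds than are shown below. What is called first, only, known or untested is meant among the compounds shown, and "the series" means these compounds.

Working notes on the series. The shared core of compound 1 `Nc1cc(N)c2nc(-c3ccccc3)c(Oc3ccc(Cl)c(Cl)c3)nc2c1` carries a phenyl group and a 3,4-dichlorophenoxy group. In a functional assay on SNB-19 cells (Homo sapiens) for inhibition, read by sulforhodamine B assay, with a stated time of 48 h (a higher number here means a weaker inhibitor of growth, a lower number a stronger inhibitor of growth), compound 1 gives 20900 nM. Two further analogues replace the dichlorophenoxy group with a larger substituent linked through sulfur or through oxygen: compound 2 `CCOC(=O)[C@H](CCC(=O)O)NC(=O)c1ccc(Sc2nc3cc(N)cc(N)c3nc2-c2ccccc2)cc1` gives 56200 nM in this assay, and compound 3 `CCOC(=O)[C@H](CCC(=O)O)NC(=O)c1ccc(Oc2nc3cc(N)cc(N)c3nc2-c2ccccc2)cc1` gives 31600 nM. The numbers of compound 1 and compound 3 lie within the scatter of one another, so no order between them is claimed; compound 2 gives a higher number than compound 1, and that gap is beyond the scatter.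

Compound 4 `Nc1cc(N)c2nc(-c3ccccc3)c(NCc3ccc(F)cc3)nc2c1` is not yet measured. Relative to compound 1 the change is (4-fluorobenzyl)amino in place of 3,4-dichlorophenoxy on an aromatic carbon. Going by the values given here, no measured pair isolates this change, so no step of the same kind is available. The step from compound 1 to compound 4 is expected to be a 1.3-fold lower number from compound 1 to compound 4 (0.12 log units; within the scatter), which is not expected to exceed the scatter in either direction. Compound 4 is expected to give about 16000 nM in this assay, with a range from 5000 nM to 55000 nM.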

Compound 4, concentration for 50% growth inhibition: 6610 nM
Estimate against measurement, compound 4: 2.4-fold (0.38 log units) above, and the stated range covers the measured number.
By their numbers in this assay, from the lowest: compound 4; then compounds 1, 3 and 2 (each within the scatter of the next, the first and the last beyond it).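

Going by these compounds alone, this is the first single-place change read at the aromatic carbon next to the ring nitrogen and ortho to the phenyl group. In this assay, (4-fluorobenzyl)amino in place of 3,4-dichlorophenoxy gives a 3.2-fold lower number from compound 1 to compound 4 (0.50 log units; beyond the scatter), so the number at this position responds to the substituent even though the two groups match in heavy-atom count and each holds one six-membered aromatic ring. The entering group also brings a hydrogen-bond donor that the leaving group lacks, and the linker and ring substituents change in the same step. Nothing available here explains the step.

From the compounds shown here alone, whether the step follows the amino linker or the fluorine remains open, and a 3,4-dichlorobenzylamino or unsubstituted benzylamino group would separate the two. Also open, going by these compounds, is how a longer chain between the nitrogen and the ring would read at this position.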